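The source may hold more compounds than are shown below. What is called first, only, known or untested is meant among the compounds shown, and "the series" means these compounds.

Measured so far in a functional assay on DU-145 cells (Homo sapiens) for antiproliferative activity, read by WST assay, with a stated time of 3 days; a lower number here means a stronger inhibitor, a higher number a weaker inhibitor:
- Compound 1 `CCCCCOc1c(-c2cc(OC)c(OC)c(OC)c2)oc2ccccc2c1=O`: > 50000 nM, a limit.
- Compound 2 `CCCCCCCOc1c(-c2cc(OC)c(OC)c(OC)c2)oc2ccccc2c1=O`: > 50000 nM, a limit.

Compound 2 has no number, only a limit, and compound 1 is in the same position: the limit of > 50000 nM in this assay, at which 2 of the 2 values shown sit. Compound 3 `COc1cc(-c2oc3ccccc3c(=O)c2OC(C)C)cc(OC)c1OC` differs from compound 2 as follows: isopropyl in place of heptyl on an oxygen on an aromatic ring. In words, this is isopropyl in place of heptyl on an oxygen on an aromatic ring.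

For the measured compounds named here, the only measured step on this chain is a step that the two limits leave unreadable from compound 1 to compound 2, and it gives no size to carry over. Going by the values given here, no step of known size therefore bears on the change. In this assay, compound 3 is expected to stay near the limit, with only a modest move towards stronger inhibition, if any. The expected change is an at least 1.2-fold lower number from compound 2 to compound 3 (0.09 log units; that floor lies within the scatter). Compound 3 is estimated at 40000 nM, with an expected range of 12000 nM to 60000 nM.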

Compound 3, half-maximal inhibitory concentration: > 50000 nM
Compound 3: a limit, no number (the forecaster's own chance of this, stated with the estimate: 60%); middle value at least 1.2-fold (0.09 log units) from the limit.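

In this assay compound 3 gives > 50000 nM as a limit. For the compounds shown here, no step among compound 1, compound 2 and compound 3 can be read: the limit of > 50000 nM in this assay, at which 3 of the 3 values shown sit.
The compounds shown leave open how pentyl, heptyl and isopropyl on this oxygen rank, and whether any gives a measurable value.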